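Changing the Aryl Group on a Thiourea Nitrogen

The compounds below may be only part of what the source reports. "The series", "measured", "known", "first", "only" and "open" are said of these compounds alone.

Of the compounds shown here, two built on a shared core have been tested in a functional assay on HeLa cells (Homo sapiens) for antiproliferative activity, with a stated time of 24 h; a lower number here means a stronger inhibitor, a higher number a weaker inhibitor. Compound 1 `Cc1ccccc1CN1CCc2c(sc(NC(=O)c3ccccc3Cl)c2C(N)=O)C1` gives > 50000 nM, which is a limit of the assay rather than a number. Compound 1 therefore sits at the limit of > 50000 nM in this assay, at which 1 of the 2 values shown sits. Compound 2 `NC(=O)c1c(NC(=O)c2ccccc2Cl)sc2c1CCN(C(=S)Nc1ccccc1C(F)(F)F)C2` gives 26700 nM, and this is the only actual number shown, so compound 2 stands as the sole measured point against which anything else can be weighed.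

Compound 3 `COc1ccc(NC(=S)N2CCc3c(sc(NC(=O)c4ccccc4Cl)c3C(N)=O)C2)cc1` is the next compound, not yet measured. It differs from compound 2 by 4-methoxyphenyl in place of 2-(trifluoromethyl)phenyl on an amide-type nitrogen. For the measured compounds named here, no measured pair shows what such a swap does, so the expected step is small. Compound 3 is expected to give 30000 nM, with a range from 9000 nM to 100000 nM. The expected step of a 1.1-fold higher number from compound 2 to compound 3 (0.05 log units; within the scatter) is estimated to stay within the usual scatter, in no clear direction.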

Compound 3, half-maximal inhibitory concentration: 36400 nM
The estimate for compound 3 lay 1.2-fold (0.08 log units) below the measured number; the range from low to high includes it.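

In this assay, putting 4-methoxyphenyl in place of 2-(trifluoromethyl)phenyl on the amide-type nitrogen gives a 1.4-fold higher number from compound 2 to compound 3 (0.13 log units; within the scatter), so this first measured swap at the position shows that these two aryl groups, one bearing fluorine and the other oxygen, cannot be told apart in this assay. The comparison with compound 1 involves a limit of the assay rather than a number, and it reads an at least 1.3-fold lower number from compound 1 to compound 3 (0.13 log units; that floor lies within the scatter), so it shows no clear effect of the change on the amine nitrogen in the ring. Compound 1 remains the one entry without an actual number: the limit of > 50000 nM in this assay, at which 1 of the 3 values shown sits.

From the compounds shown here alone, what an unsubstituted phenyl, a pyridine or an alkyl chain would do on this nitrogen remains open. So does the effect of an aryl group carrying an amine or a carboxylic acid.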